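A heavier aryl group on an already soluble series

The compounds below may be only part of what the source reports. "The series", "measured", "known", "first", "only" and "open" are said of these compounds alone.

Compound 1 `Cc1oc(-c2ccccc2Cl)nc1CN1CCC(C(=O)NCCCN2C[C@H](C)C[C@H](C)C2)CC1` is known in a physicochemical assay for solubility, in phosphate buffer, measured as kinetic solubility, at pH 7.4 (a lower number here means a less soluble compound, a higher number a more soluble compound), only as a limit: compound 1 gives > 72 ug/mL, a limit of the assay rather than a number. Compound 2 `Cc1ccccc1-c1nc(CN2CCC(C(=O)NCCCN3CCCC(C(C)C)C3)CC2)c(C)o1` likewise gives > 71 ug/mL, which is a limit. Compound 3 `Cc1ccccc1-c1nc(CN2CCC(C(=O)NCCCN3CC4CCCC(C4)C3)CC2)c(C)o1` also sits at a limit, > 71 ug/mL. Going by the values given here, the single measured step, a step that the two limits leave unreadable from compound 2 to compound 3, thus offers no readable size, and it alters a different part of the molecule. The change leading to compound 4 `COc1cccc(Br)c1-c1nc(CN2CCC(C(=O)NCCCN3C[C@H](C)C[C@H](C)C3)CC2)c(C)o1` is 2-bromo-6-methoxyphenyl in place of 2-chlorophenyl on an aromatic carbon. Among the compounds with values here, no measured step bears on this change, so the expectation rests on the limit of > 72 ug/mL in this assay, at which 1 of the 3 values shown sits, alone. Compound 4 is expected to stay near the limit, with an estimated step of an at least 1.1-fold lower number from compound 1 to compound 4 (0.04 log units; that floor lies within the scatter). The estimate for compound 4 is 65 ug/mL, ranging from 25 ug/mL to 80 ug/mL.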

Compound 4, solubility: > 83 ug/mL
Compound 4 was reported as a limit; the forecaster's own chance of this, stated with the estimate: 55%; middle value at least 1.2-fold (0.10 log units) from the limit.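

Compound 1 and compound 4 are both known only as limits, and the step between them cannot be read. The compounds shown leave open whether 2-bromo-6-methoxyphenyl in place of 2-chlorophenyl changes solubility at all.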